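Benzyl to dicarboxyphenyl swap on an amide nitrogen

The source may report more compounds than this note shows. Statements on the series, on what has been measured and on what is new or still open speak of the compounds shown alone.

Measured compounds:
compound 1, `CCCCCCCCCCOc1cc(OCCCCCCCCCC)cc(OCCCCCC(=O)N(c2cccc(C(=O)O)c2)c2cccc(C(=O)O)c2)c1`: 14%
compound 2, `CCCCCCCCCCOc1cc(OCCCCCCCCCC)cc(OCCCCCC(=O)N(Cc2ccc(C(=O)O)cc2)c2cccc(C(=O)O)c2)c1`: 92%

Among the compounds with values here, in an assay on isolated protein for binding affinity to L-selectin (Homo sapiens), read by ELISA, tested at 500 uM (a lower number here means less inhibition, a higher number more inhibition at the concentration tested (going by the name of the read-out)), compound 2 gives 92%, the higher of the two numbers measured so far; compound 1 gives 14%. Within the data shown here, the single measured step, a number 78 percentage points higher from compound 1 to compound 2 (beyond the scatter), is the only guide available. Compound 3, `CCCCCCCCCCOc1cc(OCCCCCCCCCC)cc(OCCCCCC(=O)N(c2cccc(C(=O)O)c2)c2ccc(C(=O)O)c(C(=O)O)c2)c1`, differs from compound 2 in one place: 3,4-dicarboxyphenyl in place of 4-carboxybenzyl on an amide-type nitrogen. As in compound 1, both groups on the amide-type nitrogen are then carboxyphenyl rings rather than one of them being a benzyl, and the 4-carboxybenzyl whose arrival brought the large rise is gone. Among the measured compounds shown here, no measured step covers the 3,4-dicarboxyphenyl itself, so a fall toward compound 1 is expected, with a wide margin. Compound 3 is estimated at 40% in this assay, between 10% and 85%. The expected step of a number 52 percentage points lower from compound 2 to compound 3 (beyond the scatter) is a drop beyond the scatter.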

Compound 3, a percentage reported as inhibition, at one concentration (the size of the read-out at that concentration, not a potency): 102%
Beside the measured number, compound 3's estimate is 62 percentage points below it, and the stated range ends below it.
By their numbers in this assay, from the lowest: compound 1; then compounds 2 and 3 (each within the scatter of the next).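

In this assay, the 3,4-dicarboxyphenyl group gives a change of a number 10 percentage points higher from compound 2 to compound 3 (within the scatter) when it replaces 4-carboxybenzyl on the amide-type nitrogen, so a benzyl group is not needed at this position for high inhibition. The other comparison is sharper: one carboxy in place of hydrogen on an aromatic carbon gives a number 88 percentage points higher from compound 1 to compound 3 (beyond the scatter), so a high number in this read-out can be seen with two aromatic rings directly on this nitrogen. Nothing available explains why this single carboxy matters so much.

Going by these compounds, whether a different group at that ring carbon, such as a tetrazole, a sulfonic acid or an amine, could stand in for the added carboxy remains open. A reading at one concentration also leaves open how compound 2 and compound 3 would compare in potency.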